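A few compounds are considered here, and "the series" means these few. Any claim that something is new, unique, unknown or untested is made for them only; others in the source may bear on it.

Three measured compounds share one core and differ in a single group. In a physicochemical assay for solubility, at pH 7.4 (a lower number here means a less soluble compound, a higher number a more soluble compound), compound 1 `CCc1ccc(NC(=O)Nc2cc(C)nc3ccccc23)cc1` gives 3300 nM and compound 2 `CC(=O)c1ccc(NC(=O)Nc2cc(C)nc3ccccc23)cc1` gives 3800 nM. These two values are close: a 1.2-fold higher number from compound 1 to compound 2 (0.06 log units; within the scatter). Compound 3 `Cc1ccc(NC(=O)Nc2cc(C)nc3ccccc23)cc1` gives 1300 nM, the lowest of the three numbers.

Compound 4 `Cc1cc(NC(=O)Nc2ccc(F)cc2)c2ccccc2n1` has not been measured yet. It has fluoro in place of methyl on an aromatic carbon, para to a large group (fluoro in place of methyl on an aromatic carbon). For the measured compounds named here, two measured steps bear on this change: a 2.5-fold lower number from compound 1 to compound 3 (0.40 log units; beyond the scatter), and a 2.9-fold lower number from compound 2 to compound 3 (0.47 log units; beyond the scatter). Both are modest, and neither involves fluoro, so the data offer no direct measure of this swap. A step no larger than those two is therefore expected in this assay, with a slight upward lean since compound 3 sits lowest at 1300 nM. The expected change is a 1.5-fold higher number from compound 3 to compound 4 (0.16 log units; within the scatter), which is not clearly beyond the scatter. For compound 4 the estimated value is 1900 nM. The expected range for compound 4 runs from 800 nM to 4500 nM.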

Compound 4, solubility: 3700 nM
Estimate against measurement, compound 4: 1.9-fold (0.29 log units) below, and the stated range covers the measured number.
By their numbers in this assay, from the lowest: compound 3; then compounds 1, 4 and 2 (each within the scatter of the next).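

In this assay, fluoro on this aromatic carbon, para to a large group, separates clearly from methyl: a 2.8-fold higher number from compound 3 to compound 4 (0.45 log units; beyond the scatter). Fluoro also reads alike with the two other groups, with a 1.1-fold higher number from compound 1 to compound 4 (0.05 log units; within the scatter) and a 1.0-fold lower number from compound 2 to compound 4 (0.01 log units; within the scatter), so among these four compounds only compound 3 stands apart, with steps beyond the scatter to each of the others. Heavy-atom count does not sort these numbers, since methyl and fluoro each hold one heavy atom yet give a modest gap, while fluoro, ethyl and acetyl do not differ beyond the scatter.

No measurement available here accounts for the gap between methyl and fluoro. As far as these compounds go, it remains open whether chloro, methoxy or an amine at this place would read with methyl or with the other three groups.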